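The compounds below may be only part of what the source reports. "The series", "measured", "known", "first", "only" and "open" are said of these compounds alone.

Measured in a functional assay on MCF7 cells (Homo sapiens) for antiproliferative activity, read by MTT assay, with a stated time of 72 h; a lower number here means a stronger inhibitor, a higher number a weaker inhibitor:
- compound 1 `O=C1CC2(CO1)CSC(=S)N2c1ccc(F)cc1` gives > 50 ug/mL
- compound 2 `O=C1CC2(CO1)CSC(=S)N2c1ccccc1O` gives > 50 ug/mL

Compound 1 stands at > 50 ug/mL, which is a limit of the assay and not a number. Compound 2 also reports a limit, > 50 ug/mL, so neither compound has a numerical reading. Within the data shown here, the series so far comes down to the limit of > 50 ug/mL in this assay, at which 2 of the 2 values shown sit.

The next compound to be tested is compound 3 `Cc1ccc(N2C(=S)SCC23COC(=O)C3)cc1`. It keeps the core of compound 1 and has methyl in place of fluoro on an aromatic carbon of a six-membered aromatic ring of carbon only, para to a large group (methyl in place of fluoro on an aromatic carbon).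

Among the measured compounds shown here, no measured step between compounds that differ in one place is available, so no such step can serve as a guide. In this assay, no shift beyond the usual scatter is expected, and so no direction is favoured. The expected change is a step that the limit leaves unreadable from compound 1 to compound 3. For compound 3 the estimated value is 60 ug/mL. The expected range for compound 3 runs from 25 ug/mL to 120 ug/mL.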

Compound 3, half-maximal inhibitory concentration: > 50 ug/mL
Compound 3 gave a limit, no number (the forecaster's own chance of this, stated with the estimate: 75%); the middle value does not contradict the limit.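

Compound 1 and compound 3 each report only a limit of the assay and not a number, so no step can be read between them for methyl in place of fluoro. The series still rests on one reading: the limit of > 50 ug/mL in this assay, at which 3 of the 3 values shown sit.

The compounds shown leave open how strongly any of them acts on these cells, and whether any substituent on the aromatic ring would give a numerical reading.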